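Trimming a Tert-Butyl Group on a Nucleoside Analogue

This account rests on a few compounds, and the source may have more. Where it says the series, first, only, none or still open, it means among the compounds named here.

Three compounds sharing one core were tested in a functional assay on HCT-15 cells (Homo sapiens) for cytotoxicity, read by sulforhodamine B assay, tested at 10 uM; a higher number here means more inhibition at the concentration tested (going by the name of the read-out), a lower number less inhibition. Compound 1 `CCCCCc1cc(-c2cn([C@H]3C[C@H](OC(C)=O)[C@@H](COC(C)=O)O3)c(=O)[nH]c2=O)on1` carries a pentyl chain and gives 98.7%. Compound 2 `CCc1ccc(-c2cc(-c3cn([C@H]4C[C@H](OC(C)=O)[C@@H](COC(C)=O)O4)c(=O)[nH]c3=O)on2)cc1` bears a 4-ethylphenyl group in that place and gives 92.2%. Compound 3 `CC(=O)OC[C@H]1O[C@@H](n2cc(-c3cc(-c4ccc(C(C)(C)C)cc4)no3)c(=O)[nH]c2=O)C[C@@H]1OC(C)=O` carries a 4-(tert-butyl)phenyl group and gives 53.8%, the lowest of the three numbers, with compound 2 nearest and compound 1 furthest away. The step of a number 6.5 percentage points lower from compound 1 to compound 2 (within the scatter) stays within the scatter, whereas a number 44.9 percentage points lower from compound 1 to compound 3 (beyond the scatter) and a number 38.4 percentage points lower from compound 2 to compound 3 (beyond the scatter) are large. Compound 4 `CC(=O)OC[C@H]1O[C@@H](n2cc(-c3cc(-c4ccc(C(C)C)cc4)no3)c(=O)[nH]c2=O)C[C@@H]1OC(C)=O` is the next step: hydrogen in place of methyl on a saturated chain carbon bound to an aromatic carbon and two saturated chain carbons, so that tert-butyl becomes isopropyl. The step that bears most on this is a number 38.4 percentage points lower from compound 2 to compound 3 (beyond the scatter), where growing ethyl into tert-butyl cost much inhibition; isopropyl sits between those two groups, so part of that loss is expected to be recovered. The step of a number 16.2 percentage points higher from compound 3 to compound 4 (beyond the scatter) is therefore expected to be upward and of moderate size. Compound 4 is estimated at 70%, within a range from 50% to 90%.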

Compound 4, a percentage reported as inhibition, at one concentration (the size of the read-out at that concentration, not a potency): 80.9%
For compound 4 the middle estimate is 10.9 percentage points below the measured one; low and high end bracket the measured number.
By their numbers in this assay, from the lowest: compound 3; then compound 4; then compounds 2 and 1 (each within the scatter of the next).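

In this assay, tert-butyl and ethyl no longer stand as two isolated points. Isopropyl gives an intermediate result: the removal of one methyl gives a number 27.1 percentage points higher from compound 3 to compound 4 (beyond the scatter), while the step in the other direction gives a number 11.3 percentage points lower from compound 2 to compound 4 (beyond the scatter), so among these three groups each added methyl on this carbon goes with less inhibition. Unlike the 4-ethylphenyl group, whose compound stayed within the scatter of the pentyl compound, the 4-isopropylphenyl group gives a number 17.8 percentage points lower from compound 1 to compound 4 (beyond the scatter), so a single added methyl is enough to separate these results. Nothing measured here explains this trend.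

The compounds shown leave open how an unbranched propyl chain would compare with isopropyl in this place. They also leave open whether a cyclopropyl group or an amine would fit the same trend.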